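A Small Ring in Place of a Branched Chain

A few compounds are considered here, and "the series" means these few. Any claim that something is new, unique, unknown or untested is made for them only; others in the source may bear on it.

Three compounds share one core and differ at a single aromatic carbon, and in one case at a chain carbon as well. Compound 1 `CCc1sc(N(CC2CC2)[C@H](C)c2ccc(-c3cc(C)ccc3-c3nc(=O)o[nH]3)cc2)nc1C(=O)NS(=O)(=O)C1CC1` carries an ethyl group on that aromatic carbon; in an ADME assay on the whole organism (Macaca fascicularis) for metabolic stability (a higher number here means that the compound lasts longer, a lower number that the compound disappears faster), compound 1 gives 3 h. Compound 2 `Cc1ccc(-c2nc(=O)o[nH]2)c(-c2ccc([C@@H](C)N(CC3CC3)c3nc(C(=O)NS(=O)(=O)C4CC4)c(C(C)C)s3)cc2)c1` carries isopropyl there and also a methyl on a saturated chain carbon; in this assay compound 2 gives 2.4 h. Compound 3 `Cc1ccc(-c2nc(=O)o[nH]2)c(-c2ccc([C@@H](C)N(CC3CC3)c3nc(C(=O)NS(=O)(=O)C4CC4)c(C4CCC4)s3)cc2)c1` carries cyclobutyl; in this assay compound 3 gives 2.8 h. On the numbers shown compound 2 sits at the low end of the trio, yet the spread is small: a 1.3-fold lower number from compound 1 to compound 2 (0.10 log units; within the scatter) and a 1.2-fold higher number from compound 2 to compound 3 (0.07 log units; within the scatter), and a 1.1-fold lower number from compound 1 to compound 3 (0.03 log units; within the scatter), so all three lie within the scatter of one another.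

Compound 4 `Cc1ccc(-c2nc(=O)o[nH]2)c(-c2ccc([C@@H](C)N(CC3CC3)c3nc(C(=O)NS(=O)(=O)C4CC4)c(C4CC4)s3)cc2)c1` has not been measured. It differs from compound 2 in one place: cyclopropyl in place of isopropyl on an aromatic carbon. Within the data shown here, the closest precedent is the ring-for-chain exchange a 1.2-fold higher number from compound 2 to compound 3 (0.07 log units; within the scatter), and the ethyl-to-cyclobutyl exchange a 1.1-fold lower number from compound 1 to compound 3 (0.03 log units; within the scatter) tells the same story: neither moved the half-life beyond the scatter. A cyclopropyl ring is therefore expected to behave alike, and the step of a 1.1-fold higher number from compound 2 to compound 4 (0.03 log units; within the scatter) is expected to stay within the scatter. Compound 4 is estimated at 2.6 h, in a range from 1.5 h to 4.5 h.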

Compound 4, half-life: 3.1 h
Compound 4: the middle estimate sits 1.2-fold (0.08 log units) below what was measured, and the stated range covers the measured number.
By their numbers in this assay, from the lowest: compounds 2, 3, 1 and 4 (each within the scatter of the next).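

Cyclopropyl in place of isopropyl keeps the count of three carbon atoms and adds a three-membered ring on the carbon next to the ring sulfur, and in this assay this gives a 1.3-fold higher number from compound 2 to compound 4 (0.11 log units; within the scatter). Cyclopropyl also stays close to the other two groups: the exchange for cyclobutyl gives a 1.1-fold higher number from compound 3 to compound 4 (0.04 log units; within the scatter), and the exchange for ethyl gives a 1.0-fold higher number from compound 1 to compound 4 (0.01 log units; within the scatter). Thus, across the four compounds shown, a three-membered ring, a four-membered ring, and the open chains ethyl and isopropyl at this position all give half-lives within the scatter of one another, and no measurement is available to explain this lack of separation.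

All four groups are built only of carbon and hydrogen, so the compounds shown leave open whether an amine, an alcohol or a carboxylic acid at this carbon would give a half-life beyond the scatter. They also leave open whether a longer chain such as hexyl, or a larger ring such as cyclohexyl, would do so, since the present set spans only small carbon groups.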